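The source may report more compounds than this note shows. Statements on the series, on what has been measured and on what is new or still open speak of the compounds shown alone.

In a functional assay on SMMC-7721 cells (Homo sapiens) for cytotoxicity, read by MTT assay, with a stated time of 72 h (a lower number here means a stronger inhibitor, a higher number a weaker inhibitor), compound 1 `O=C(CCl)Nc1ccc(C(=O)/C=C/c2cccc(Cl)c2)cc1` gives 7760 nM and compound 2 `O=C(CSC(=S)N[C@H]1CCOC1=O)Nc1ccc(C(=O)/C=C/c2ccccc2Cl)cc1` gives 20400 nM, the higher of the two numbers, with the gap beyond the scatter. Compound 3 `O=C(CSC(=S)N[C@H]1CCOC1=O)Nc1ccc(C(=O)/C=C/c2cccc(Cl)c2)cc1` differs from compound 2 by 3-chlorophenyl in place of 2-chlorophenyl on a double-bonded chain carbon bound to a double-bonded chain carbon. Among the compounds with values here, no measured pair isolates this change, so the size of the step has no direct precedent. The expected change is small, an estimated 1.3-fold lower number from compound 2 to compound 3 (0.11 log units; within the scatter), and not beyond the scatter. For compound 3 the expected value in this assay is 16000 nM, with an estimated range of 7000 nM to 35000 nM.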

Compound 3, half-maximal inhibitory concentration: 39100 nM
Beside the measured number, compound 3's estimate is 2.4-fold (0.39 log units) below it; the measured number lies above the stated range.
By their numbers in this assay, from the lowest: compound 1; then compounds 2 and 3 (each within the scatter of the next).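

In this assay, 3-chlorophenyl in place of 2-chlorophenyl on a double-bonded chain carbon bound to a double-bonded chain carbon gives (a 1.9-fold higher number from compound 2 to compound 3 (0.28 log units; within the scatter)), so these two chlorophenyl isomers are not separated here. Within the data shown here, with 3-chlorophenyl held constant, the group of 10 heavy atoms in place of one chlorine atom, on a saturated chain carbon bound to a carbonyl carbon, gives (a 5.0-fold higher number from compound 1 to compound 3 (0.70 log units; beyond the scatter)), the only step here beyond the scatter. Nothing available bears on the reason for either step.

Still open, as far as these compounds go, is how a plain phenyl would read at the double-bonded chain carbon. Also open, from the compounds shown here alone, is how an amine would read in place of the chlorine on the saturated chain carbon.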